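The source may hold more compounds than are shown below. What is called first, only, known or untested is meant among the compounds shown, and "the series" means these compounds.

Measured so far in a physicochemical assay for lipophilicity, read by HPLC, measured as octanol-water partition; on this read-out lower numbers stand for lower lipophilicity and higher numbers for higher lipophilicity:

compound 1 `NC(=O)c1c(COc2ccccc2/C=N/NC(=O)c2ccncc2)no[n+]1[O-]` — compound 1 gives 1.3
compound 2 `O=C(N/N=C/c1ccc2no[n+]([O-])c2c1)c1ccccc1O` — compound 2 gives 1.3
compound 3 `CC(C)(C)c1ccc(C(=O)N/N=C/c2ccc3no[n+]([O-])c3c2)cc1` — compound 3 gives 3.8

Compound 2 stands level with compound 1 at the digits shown, and the two together are the lowest of the three numbers; the gap between them is within the scatter, so no order is claimed. Compound 3 lies a good deal higher than compound 2, beyond the scatter.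

Compound 4 `O=C(N/N=C/c1ccc2no[n+]([O-])c2c1)c1cccc(O)c1` has not yet been measured in this assay. Set against compound 2 the change is 3-hydroxyphenyl in place of 2-hydroxyphenyl on a carbonyl carbon

Both groups carry the same counted atoms, donors and acceptors, so only the arrangement on the hydroxyphenyl ring moves. For the measured compounds named here, no measured pair in the set isolates a shift of this kind, so the expectation rests on the identity of what leaves and what enters. The step is expected to be small, if anything a slight fall, and likely within the scatter: a number 0.20 log units lower from compound 2 to compound 4 (within the scatter) is expected. For compound 4 the estimate in this assay is 1.1, with a range from 0.6 to 1.6.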

Compound 4, partition coefficient: 1.2
Compound 4: the middle estimate sits 0.10 log units below what was measured; measured number inside the range.
By their numbers in this assay, from the lowest: compounds 4, 1 and 2 (each within the scatter of the next); then compound 3.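

In this assay, for the compounds shown here, 3-hydroxyphenyl in place of 2-hydroxyphenyl on a carbonyl carbon gives a number 0.10 log units lower from compound 2 to compound 4 (within the scatter), the first step read between compounds that differ in one place. Both groups have the same counted atoms, donors and acceptors, so at this position a rearrangement alone leaves the read-out inside the scatter, and the two compounds are not separated. Nothing available here bears on why the two groups read alike.

Going by these compounds, whether an aminophenyl or a carboxyphenyl group on the same carbonyl carbon would also stay within the scatter remains open. Also open, on these data alone, is whether the same rearrangement of the hydroxyphenyl group would read alike on the core of compound 1.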